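The compounds below may be only part of what the source reports. "The series", "measured", "known", "first", "only" and "open" are said of these compounds alone.

In a functional assay on CCRF-CEM cells (Homo sapiens) for inhibition, read by cell counting, with a stated time of 72 h (a higher number here means a weaker inhibitor, a lower number a stronger inhibitor), compound 3 (`CCN(CC)CN1C(=O)/C(=N/NC(=S)Nc2ccccc2)c2ccccc21`) gives 11000 nM and sits level with compound 1 (`CCN(CC)CN1C(=O)/C(=N/NC(=S)Nc2ccc(Cl)cc2)c2ccccc21`) at 10000 nM while compound 2 (`CCN(CC)CN1C(=O)/C(=N/NC(N)=S)c2cc(Cl)ccc21`) stands clearly higher at 71000 nM in this set. Compound 4 (`CCN(CC)CN1C(=O)/C(=N/NC(N)=S)c2ccccc21`) has hydrogen in place of phenyl on an amide-type nitrogen and so goes from anilino to amino. Going by the values given here, no measured step covers this change. The only one, a 1.1-fold higher number from compound 1 to compound 3 (0.04 log units; within the scatter) for hydrogen in place of chloro on an aromatic carbon, stays within the scatter, though that chloro sits elsewhere. The nearest guide is compound 2 at 71000 nM as it too has the amino end, with a chloro on the core. The expected step is a 4.5-fold higher number from compound 3 to compound 4 (0.66 log units; beyond the scatter) and would lie beyond the scatter. Compound 4 is estimated at 50000 nM with an expected range from 20000 nM to 110000 nM overall.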

Compound 4, half-maximal inhibitory concentration: 164000 nM
Compound 4: middle estimate off by 3.3-fold (0.52 log units), on the low side, outside the stated range (above it).
By their numbers in this assay, from the lowest: compounds 1 and 3 (each within the scatter of the next); then compound 2; then compound 4.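

In this assay, the amide-type nitrogen proves to be the most sensitive place in this set, since going from anilino to amino gives a 15-fold higher number from compound 3 to compound 4 (1.17 log units; beyond the scatter), and the loss of 4-chlorophenyl gives a 16-fold higher number from compound 1 to compound 4 (1.21 log units; beyond the scatter). Hydrogen in place of chloro matters much less, even with a 2.3-fold higher number from compound 2 to compound 4 (0.36 log units; beyond the scatter), and the effect of that exchange cannot be told apart between the two cores: the same change on two cores in this assay, a 1.1-fold higher number (0.04 log units; within the scatter) from compound 1 to compound 3 and a 2.3-fold higher number (0.36 log units; beyond the scatter) from compound 2 to compound 4, 2.1-fold (0.32 log units) apart, within the scatter of two such steps.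

From the compounds shown here alone, it stays open whether a phenyl ring is needed on that nitrogen, or whether methyl, benzyl or a longer chain would serve as well.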